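The source may hold more compounds than are shown below. What is called first, only, known or untested is meant among the compounds shown, and "the series" means these compounds.

Measured in a functional assay on HL-60 cells (Homo sapiens) for antiproliferative activity, with a stated time of 72 h; a higher number here means a weaker inhibitor, a lower number a stronger inhibitor:
compound 1 `Nc1ncnn2c([C@@H]3O[C@H](CO)[C@@H](O)[C@H]3O)cc(C#CC3CC3)c12`: 40 nM
compound 2 `Nc1ncnn2c([C@@H]3O[C@H](CO)[C@@H](O)[C@H]3O)cc(C#Cc3ccccc3)c12`: > 100000 nM, a limit of the assay, not a number
compound 3 `Nc1ncnn2c([C@@H]3O[C@H](CO)[C@@H](O)[C@H]3O)cc(-c3ccc(Cl)cc3)c12`: 37900 nM

Compound 2 stands at the upper edge of the set. For compound 2 only a limit is known in this assay, (the limit of > 100000 nM in this assay, at which 1 of the 3 values shown sits), so no numerical value can be placed on it; the two steps that involve it, an at least 2500-fold higher number from compound 1 to compound 2 (3.39 log units; beyond the scatter) and an at least 2.6-fold lower number from compound 2 to compound 3 (0.42 log units; beyond the scatter), are both beyond the scatter and both point to compound 2 as the weakest of the three.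

Compound 4 `Nc1ncnn2c([C@@H]3O[C@H](CO)[C@@H](O)[C@H]3O)cc(-c3ccccc3F)c12` is not yet measured. Its change from compound 2 is 2-fluorophenyl in place of 2-phenylethynyl on an aromatic carbon.

The step that bears on it most directly is an at least 2.6-fold lower number from compound 2 to compound 3 (0.42 log units; beyond the scatter), where the same 2-phenylethynyl group gives way to a directly attached aryl, there 4-chlorophenyl, and the number falls by at least a modest amount out of the limit. The step of a 950-fold higher number from compound 1 to compound 3 (2.98 log units; beyond the scatter) shows that a directly attached aryl remains far weaker than 2-cyclopropylethynyl. Compound 4 also carries a directly attached aryl, 2-fluorophenyl, so the expected step in this assay from compound 2 to compound 4 is an at least 3.3-fold lower number from compound 2 to compound 4 (0.52 log units; beyond the scatter), a lower number, of about the size seen for compound 3. Compound 4 is therefore estimated at 30000 nM, within a range of 5000 nM to 150000 nM, with a real chance that only a limit is returned.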

Compound 4, half-maximal inhibitory concentration: > 100000 nM
Compound 4: only a limit was reported; the forecaster's own chance of this, stated with the estimate: 30%; middle value at least 3.3-fold (0.52 log units) away from the limit.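

In this assay compound 4 is reported only as a limit of the assay, not a number, and the step that joins it to compound 2 cannot be read: the limit of > 100000 nM in this assay, at which 2 of the 4 values shown sit.

A directly attached aryl on this aromatic carbon does not in itself give a measurable value, and the aryl's substitution matters: exchanging 4-chlorophenyl for 2-fluorophenyl gives an at least 2.6-fold higher number from compound 3 to compound 4 (0.42 log units; beyond the scatter). Compound 1 now stands further apart as the strongest of the four, with 2-fluorophenyl in place of 2-cyclopropylethynyl giving an at least 2500-fold higher number from compound 1 to compound 4 (3.39 log units; beyond the scatter).

Compound 3 and compound 4 differ in both the halogen and where it sits on the phenyl ring, so the shown compounds cannot separate these two changes; a 4-fluorophenyl or 2-chlorophenyl group at this position would do so. As far as these compounds go, it also remains open whether the strength of compound 1 depends on the cyclopropyl group specifically, which an ethynyl group carrying a cyclobutyl, a tert-butyl or a longer alkyl chain would test.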